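A few compounds are considered here, and "the series" means these few. Any claim that something is new, unique, unknown or untested is made for them only; others in the source may bear on it.

Of the compounds shown here, two have so far been tested in an assay on HEK293 cells for positive allosteric modulation of metabotropic glutamate receptor 2 (Rattus norvegicus), read by thallium flux; on this read-out lower numbers stand for an effect already at smaller amounts and higher numbers for an effect only at larger amounts of compound. Compound 1, `O=C(O)c1cc(-c2cccc(COc3ccc4c(=O)n(CC5CC5)sc4c3)c2)ccc1Cl`, gives 2480 nM in this assay. Compound 2, `O=C(O)c1cc(-c2cccc(COc3ccc4c(c3)CN(C3CCCC3)C4=O)c2)ccc1O`, gives 20 nM in this assay. Of the two numbers, compound 2 has the lower one, and the gap between compound 2 and compound 1 lies well beyond the usual scatter, so compound 2 acts at clearly smaller amounts than compound 1. These two compounds differ in several places at once, so their two values alone do not show which single change matters.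

Compound 3, `COc1ccc(-c2cccc(COc3ccc4c(c3)CN(C3CCCC3)C4=O)c2)cc1C(=O)O`, is the next compound to be measured. It differs from compound 2 in one spot only: methyl in place of hydrogen on an oxygen on an aromatic ring. For the measured compounds named here, no single-change step of this kind has been measured here, so the direction is open. The expectation for the step from compound 2 to compound 3 in this assay is a moderate rise, a 3.0-fold higher number from compound 2 to compound 3 (0.48 log units; beyond the scatter), with a chance that it stays within the scatter. Compound 3 is estimated to give 60 nM in this assay, with a range from 15 nM to 300 nM.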

Compound 3, half-maximal effective concentration: 170 nM
For compound 3 the middle estimate is 2.8-fold (0.45 log units) below the measured one; low and high end bracket the measured number.
By their numbers in this assay, from the lowest: compound 2; then compound 3; then compound 1.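

In this assay, replacing hydroxy with methoxy, which turns 3-carboxy-4-hydroxyphenyl into 3-carboxy-4-methoxyphenyl, gives an 8.5-fold higher number from compound 2 to compound 3 (0.93 log units; beyond the scatter). For the compounds shown here, this is the first step here that changes only one place, and it shows that this position responds to a small change: adding a single methyl on the oxygen carries the number beyond the usual scatter, so the free hydroxy form acts at smaller amounts than the methoxy form, although compound 3 still gives a measurable 170 nM. Nothing measured here explains this difference, and no independent data bear on it.

One step cannot show whether the loss of the hydrogen or the arrival of the methyl drives the rise, and an amine or a longer chain such as ethoxy at this place would help separate the two. On these data alone, it also remains open whether the same change would give a step of similar size on a different core, such as the core of compound 1.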